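This account rests on a few compounds, and the source may have more. Where it says the series, first, only, none or still open, it means among the compounds named here.

Compound 1 `CCn1nc(C)c2c(C)cc(=O)oc21`: 24.9 mg/kg 
Compound 2 `Cc1cc(O)oc2nnc(CC(=O)O)c1-2`: > 100 mg/kg 

Among the compounds with values here, only two compounds have been measured in a functional assay on the whole organism with Mus musculus as the target, in the writhing test; a lower number here means that less compound is needed, a higher number that more compound is needed for the effect. Within the data shown here, compound 1 gives 24.9 mg/kg, the only actual number obtained. Compound 2 reaches only a limit of the assay, > 100 mg/kg, so the limit of > 100 mg/kg in this assay, at which 1 of the 2 values shown sits, and compound 1 stands alone with a number.

Compound 3 `Cc1cc(=O)oc2c1c(C)nn2C` differs from compound 1 by hydrogen in place of methyl on a saturated chain carbon bound to an aromatic nitrogen. Among the measured compounds shown here, no measured step of this kind exists here. The step from compound 1 to compound 3 in this assay is expected to be small, a 1.0-fold higher number from compound 1 to compound 3 (0.00 log units; within the scatter), not beyond the usual scatter. Compound 3 is estimated at 25 mg/kg, between 9 mg/kg and 70 mg/kg.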

Compound 3, dose for half-maximal effect: 11.6 mg/kg
Beside the measured number, compound 3's estimate is 2.2-fold (0.33 log units) above it; the range from low to high includes it.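

Within the data shown here, the change from ethyl to methyl gives a 2.1-fold lower number from compound 1 to compound 3 (0.33 log units; beyond the scatter) in this assay and is the first measured step at this position. It shows that the number in this assay responds to the loss of a single carbon here, with less compound needed for the shorter chain, though the step is modest. Nothing shown here accounts for this step. As far as these compounds go, whether a longer chain such as propyl would move the number the other way stays open. So does the effect of an amine in place of the methyl.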